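Methoxy added to compound 3: expected effect

This account rests on a few compounds, and the source may have more. Where it says the series, first, only, none or still open, it means among the compounds named here.

Compound 3 `Cn1nc(N)c2c(=O)[nH]c(-c3ccccc3)cc21` gives 16% in an assay on isolated protein for inhibition of serine/threonine-protein kinase Chk2 (Homo sapiens), read by mobility shift assay, tested at 30 uM; on this read-out lower numbers stand for less inhibition and higher numbers for more inhibition at the one concentration tested (going by the name of the read-out). Among the three numbers so far it stands second: compound 2 `Cc1cc2c(c(N)nn2C)c(=O)[nH]1` gives 3%, and compound 1 `COc1cccc(-c2cc3[nH]nc(N)c3c(=O)[nH]2)c1` gives 52%. Within the data shown here, the one step measured between compounds differing in a single place, a number 13 percentage points higher from compound 2 to compound 3 (beyond the scatter), came from phenyl in place of methyl on an aromatic carbon. Compound 4 `COc1cccc(-c2cc3c(c(N)nn3C)c(=O)[nH]2)c1` differs from compound 3 by methoxy in place of hydrogen on an aromatic carbon. Among the measured compounds shown here, no measured step bears directly on this change. For the measured compounds named here, compound 1 carries the same methoxy, but it also differs from compound 4 at a second place, so compound 1 shows with its 52% only that a methoxy-bearing member of the series can reach that level; it does not isolate the methoxy. The expected step is therefore uncertain and leans upward, a number 10 percentage points higher from compound 3 to compound 4 (within the scatter). Compound 4 is estimated at 26%, with a range from 8% to 46%.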

Compound 4, a percentage reported as inhibition, at one concentration (the size of the read-out at that concentration, not a potency): 31%
The estimate for compound 4 lay 5 percentage points below the measured number; low and high end bracket the measured number.
By their numbers in this assay, from the lowest: compound 2; then compound 3; then compound 4; then compound 1.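

In this assay, methoxy in place of hydrogen on an aromatic carbon of a six-membered aromatic ring of carbon only, meta to a large group, gives a number 15 percentage points higher from compound 3 to compound 4 (beyond the scatter), so this place on the phenyl responds to substitution when the aromatic nitrogen carries methyl. With the methoxy held fixed, methyl in place of hydrogen on an aromatic nitrogen gives a number 21 percentage points lower from compound 1 to compound 4 (beyond the scatter), which separates the nitrogen change from the methoxy change and shows that the hydrogen form reads higher in this pair. Nothing available here accounts for either step.

Open, from the compounds shown here alone, is whether the methoxy step carries over when hydrogen sits on that aromatic nitrogen. Also open, going by these compounds, is whether an amine, a carboxylic acid or a longer chain such as ethoxy at this place would move the number as methoxy does.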